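Aryl variation on the most inhibitory chalcone-triazole-coumarin member

The compounds below may be only part of what the source reports. "The series", "measured", "known", "first", "only" and "open" are said of these compounds alone.

Compound 2 `COc1cc(/C=C/C(=O)/C=C/c2cc(OC)c(OC)c(OC)c2)ccc1OCc1cn(CCOc2cc(=O)oc3ccccc23)nn1` stands highest of the three numbers in a functional assay on THP-1 cells (Homo sapiens) for inhibition, read by sulforhodamine B assay, with a stated time of 48 h, tested at 50 uM; on this read-out lower numbers stand for less inhibition of growth and higher numbers for more inhibition of growth at the one concentration tested; in this assay compound 2 gives 99%. Compound 3 `COc1cc(/C=C/C(=O)/C=C/c2cc(OC)c(OC)c(OC)c2)ccc1OCc1cn(CCCCCOc2cc(=O)oc3ccccc23)nn1` gives 55%, and compound 1 `COc1cc(/C=C/C(=O)/C=C/c2ccccc2)ccc1OCc1cn(CCCOc2cc(=O)oc3ccccc23)nn1` gives 48%; both gaps to compound 2 lie beyond the scatter. Among the measured compounds shown here, no two measured compounds differ in one place only, so the aryl change is not isolated by any measured pair. Compound 4 `COc1ccc(/C=C/C(=O)/C=C/c2ccc(OCc3cn(CCOc4cc(=O)oc5ccccc45)nn3)c(OC)c2)cc1` keeps the rest of compound 2 and changes (4-methoxyphenyl in place of 3,4,5-trimethoxyphenyl on a double-bonded chain carbon bound to a double-bonded chain carbon). Since compound 1, which also lacks the 3,4,5-trimethoxyphenyl, gives 48%, a drop beyond the scatter is expected, estimated as a number 29 percentage points lower from compound 2 to compound 4 (beyond the scatter). Compound 4 is accordingly expected to give about 70%, within 40% to 95%.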

Compound 4, percent growth inhibition at one concentration: 78%
Beside the measured number, compound 4's estimate is 8 percentage points below it, and the stated range covers the measured number.
By their numbers in this assay, from the lowest: compounds 1 and 3 (each within the scatter of the next); then compound 4; then compound 2.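

In this assay, among the compounds shown here, the first readable change at the place on a double-bonded chain carbon bound to a double-bonded chain carbon gives a number 21 percentage points lower from compound 2 to compound 4 (beyond the scatter), so the aryl group there affects growth inhibition at the one concentration tested. With 4-methoxyphenyl in that place, compound 4 still gives 78%, so inhibition does not depend entirely on the 3,4,5-trimethoxyphenyl. No measurement here accounts for the step.

Going by these compounds, whether a 4-hydroxyphenyl or a 3,4-dimethoxyphenyl at this place would fall nearer compound 2 or compound 4 stays open. So does whether the step holds with a longer chain on the triazole.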